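The source may report more compounds than this note shows. Statements on the series, on what has been measured and on what is new or still open speak of the compounds shown alone.

Measured compounds:
- Compound 1 `CCOC(=O)c1ccc(-c2nn(Cc3cccc(OC)c3)c3ccccc23)cc1`: in a functional assay on cells (Platelet, Homo sapiens) for inhibition (on this read-out lower numbers stand for stronger inhibition and higher numbers for weaker inhibition), compound 1 gives > 10000 nM, which is a limit of the assay and not a number.
- Compound 2 `CCCn1nc(-c2ccc(C(=O)OCC)cc2)c2ccccc21`: in this assay compound 2 gives > 10000 nM, again a limit of the assay.

Within the data shown here, the only step between these two, a step that the two limits leave unreadable from compound 1 to compound 2, cannot be read, since both ends are limits. Compound 2 therefore stands at the limit of > 10000 nM in this assay, at which 2 of the 2 values shown sit, with no number of its own.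

Compound 3 `CCOC(=O)c1ccc(-c2nn(-c3ccccc3)c3ccccc23)cc1` differs from compound 2 in one place: phenyl in place of propyl on an aromatic nitrogen. Among the measured compounds shown here, no measured step concerns this change, and the one step that exists does not read at all. There is thus no ground to expect a readable number, and the expectation for compound 3 is that it also returns a limit. The estimate for compound 3 in this assay is 15000 nM, in a range from 3000 nM to 100000 nM. This means an expected step that the limit leaves unreadable from compound 2 to compound 3, which is no change beyond what can be read.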

Compound 3, half-maximal inhibitory concentration: > 10000 nM
Compound 3: a limit, no number; the forecaster's own chance of this, stated with the estimate: 80%; the middle value does not contradict the limit.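

No step among compound 1, compound 2 and compound 3 can be read, since each gives a limit of the assay and not a number in this assay: the limit of > 10000 nM in this assay, at which 3 of the 3 values shown sit.

The compounds shown leave open whether any group on that aromatic nitrogen of the shared core gives a readable number.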